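Amide to Ester at the Carbonyl Carbon

The compounds below may be only part of what the source reports. "The series", "measured", "known", "first", "only" and "open" are said of these compounds alone.

Three compounds share one core. Compound 1 `CC1=C(C(=O)OC(C)(C)C)C(c2ccoc2)NC(=O)N1` gives 2% in an assay on membranes from HeLa cells for displacement of a labelled ligand from adenosine receptor A3 (Homo sapiens), read by scintillation counting, with a stated time of 180 min, tested at 1 uM; on this read-out lower numbers stand for less inhibition and higher numbers for more inhibition at the one concentration tested (going by the name of the read-out); compound 2 `CC1=C(C(=O)C2CC2)C(c2ccoc2)NC(=O)N1` gives 16%; compound 3 `CCN(CC)C(=O)C1=C(C)NC(=O)NC1c1ccoc1` gives 37%, the highest of the three, with compound 2 nearest (a number 21 percentage points higher from compound 2 to compound 3 (beyond the scatter)) and compound 1 furthest (a number 35 percentage points higher from compound 1 to compound 3 (beyond the scatter)). Compound 4 `CCC(C)OC(=O)C1=C(C)NC(=O)NC1c1ccoc1` differs from compound 3 in one place: sec-butoxy in place of diethylamino on a carbonyl carbon. Among the compounds with values here, the step that bears on this is the one from compound 1, which also carries an alkoxy group on that carbonyl carbon, a number 35 percentage points higher from compound 1 to compound 3 (beyond the scatter). Reversing that change with a closely related alkoxy group, a large fall is expected, a number 31 percentage points lower from compound 3 to compound 4 (beyond the scatter). Compound 4 is therefore estimated at 6%, within 0% to 20%.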

Compound 4, a percentage reported as inhibition, at one concentration (the size of the read-out at that concentration, not a potency): 11%
Beside the measured number, compound 4's estimate is 5 percentage points below it; low and high end bracket the measured number.
By their numbers in this assay, from the lowest: compounds 1, 4 and 2 (each within the scatter of the next, the first and the last beyond it); then compound 3.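

Sec-butoxy in place of diethylamino on the carbonyl carbon gives a clear loss (a number 26 percentage points lower from compound 3 to compound 4 (beyond the scatter)), so the low number of the tert-butoxy ester is not confined to that one alkoxy group. Sec-butyl in place of tert-butyl on the oxygen makes no readable difference (a number 9 percentage points higher from compound 1 to compound 4 (within the scatter)), and the same holds for sec-butoxy in place of cyclopropyl (a number 5 percentage points lower from compound 2 to compound 4 (within the scatter)). Nothing available explains the gap between the diethylamino amide and the esters.

Open, from the compounds shown here alone, is whether another amine at this carbonyl carbon, such as dimethylamino or piperidine, would match or pass diethylamino.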